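From Chloro to Fluoro on the Outer Aromatic Ring

This account rests on a few compounds, and the source may have more. Where it says the series, first, only, none or still open, it means among the compounds named here.

Compound 2 `O=C(NOCc1ccccc1F)c1cn(-c2ccccc2)nc1-c1ccc(Cl)cc1` and compound 1 `COc1ccc(-c2nn(-c3ccccc3)cc2C(=O)NOCc2ccccc2F)cc1` share one core and differ in a single group on the outer six-membered aromatic ring. In a functional assay on HeLa cells (Homo sapiens) for antiproliferative activity, read by MTT assay, with a stated time of 48 h, in the presence of a further agent that is not named here (a lower number here means a stronger inhibitor of growth, a higher number a weaker inhibitor of growth), compound 1 gives 2900 nM, and in this assay compound 2 gives 4170 nM. The step of a 1.4-fold higher number from compound 1 to compound 2 (0.16 log units; within the scatter) lies within the scatter, so the two compounds are effectively level, and compound 2 has no measured neighbour from which it stands apart.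

Compound 3 `O=C(NOCc1ccccc1F)c1cn(-c2ccccc2)nc1-c1ccc(F)cc1` is the next step: fluoro in place of chloro on an aromatic carbon. Among the measured compounds shown here, the only step measured so far, a 1.4-fold higher number from compound 1 to compound 2 (0.16 log units; within the scatter), replaced a methoxy by a chloro on that same carbon and left the number essentially unchanged; a second exchange at that carbon, now from chloro to fluoro, is therefore expected to produce no shift beyond the scatter. The expected step is a 1.2-fold higher number from compound 2 to compound 3 (0.08 log units; within the scatter). For compound 3 the estimate in this assay is 5000 nM, with a range from 2500 nM to 10000 nM.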

Compound 3, concentration for 50% growth inhibition: 10300 nM
Estimate against measurement, compound 3: 2.1-fold (0.31 log units) below, outside the stated range (above it).
By their numbers in this assay, from the lowest: compounds 1 and 2 (each within the scatter of the next); then compound 3.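

In this assay, among the compounds shown here, the exchange of chloro for fluoro gives a 2.5-fold higher number from compound 2 to compound 3 (0.39 log units; beyond the scatter), the first step at this aromatic carbon to clear the scatter, so the group there can change the number after all. Set against methoxy, fluoro gives a 3.6-fold higher number from compound 1 to compound 3 (0.55 log units; beyond the scatter), which makes compound 3 the weakest inhibitor of growth of the three, although both steps are only modest. Nothing shown here accounts for this difference.

From the compounds shown here alone, what an amine, a carboxylic acid or a longer chain such as butoxy would do on this same carbon remains open. Going by these compounds, it is also open whether fluoro in place of chloro would give a similar step if the shared core carried a different group elsewhere.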